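The compounds below may be only part of what the source reports. "The series", "measured", "known", "first", "only" and "open" are said of these compounds alone.

Compound 1 `NC1=NC2(CCSCC2)N(OCCCOc2cccc(Cl)c2)C(N)=N1` is the starting point here. For the measured compounds named here, in a functional assay on MDA-MB-231 cells (Homo sapiens) for antiproliferative activity, read by MTT assay, with a stated time of 72 h (a higher number here means a weaker inhibitor, a lower number a stronger inhibitor), compound 1 gives 130 nM and stands alone, as the only number available. For compound 2 `NC1=NC2(CCOCC2)N(OCCCOc2ccc(Cl)cc2Cl)C(N)=N1` the entry reads "not determined" (no result reported). For compound 3 `NC1=NC2(CCOCC2)N(OCCCOc2cc(Cl)c(Cl)cc2Cl)C(N)=N1` the entry reads "not determined" (no result reported). So compound 1 cannot yet be ranked against anything. The next compound, compound 4 `NC1=NC2(CCSCC2)N(OCCCOc2ccccc2Cl)C(N)=N1`, keeps the core of compound 1 and changes only where the chlorine sits on the ring. The difference 2-chlorophenyl in place of 3-chlorophenyl on an oxygen on a saturated carbon is 2-chlorophenyl in place of 3-chlorophenyl, on an oxygen on a saturated carbon. Going by the values given here, no measured pair shows what such a change does, so no step beyond the usual scatter is expected. The expected change a 1.4-fold higher number from compound 1 to compound 4 (0.14 log units; within the scatter) is therefore small. The estimated value for compound 4 is 180 nM with an expected range from 60 nM to 540 nM in this estimate.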

Compound 4, half-maximal inhibitory concentration: 80 nM
Beside the measured number, compound 4's estimate is 2.3-fold (0.35 log units) above it; measured number inside the range.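

In this assay, for the compounds shown here, the swap of 3-chlorophenyl for 2-chlorophenyl on an oxygen on a saturated carbon gives the first measured pair (a 1.6-fold lower number from compound 1 to compound 4 (0.21 log units; within the scatter)). At this position, the two placements of the chlorine therefore cannot be told apart in this read-out. Nothing measured here offers an explanation for this result. Still open, going by these compounds, is how 4-chlorophenyl would compare, and whether an amine or a carboxylic acid in place of the chlorine would give a clear step.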